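From (Piperidin-1-yl)carbonyl to Ethylcarbamoyl: Permeability Outlook

The compounds below may be only part of what the source reports. "The series", "measured", "known", "first", "only" and "open" are said of these compounds alone.

Of the compounds shown here, two built on one shared core have been measured in an ADME assay on Caco-2 cells (Homo sapiens) for permeability, in the apical to basolateral direction; a lower number here means that the compound crosses the layer more slowly, a higher number that the compound crosses the layer faster. Compound 1, `CCC(=O)N1CCC(CN(C2Cc3cc(C#N)ccc3N(Cc3cncn3C)C2)S(=O)(=O)c2ccccn2)CC1`, gives 0.5 10^-6 cm/s. Compound 2, `Cn1cncc1CN1CC(N(CC2CCN(C(=O)N3CCCCC3)CC2)S(=O)(=O)c2ccccn2)Cc2cc(C#N)ccc21`, gives 0.6 10^-6 cm/s. On these two numbers compound 2 sits alongside compound 1, the step of a 1.2-fold higher number from compound 1 to compound 2 (0.08 log units; within the scatter) between them being too small to separate them.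

Compound 3, `CCNC(=O)N1CCC(CN(C2Cc3cc(C#N)ccc3N(Cc3cncn3C)C2)S(=O)(=O)c2ccccn2)CC1`, has not yet been measured. Its change from compound 2 is ethylamino in place of piperidin-1-yl on a carbonyl carbon. Among the measured compounds shown here, the only measured step, a 1.2-fold higher number from compound 1 to compound 2 (0.08 log units; within the scatter), concerns the same carbonyl carbon and shows that exchanging ethyl for piperidin-1-yl there left this assay unchanged within scatter. For the measured compounds named here, that step bears on compound 3 only loosely: ethylamino carries a hydrogen-bond donor, which neither ethyl nor piperidin-1-yl does, and no measured pair shows what such a donor does on this core. The account therefore expects for compound 3 a step of a 1.5-fold lower number from compound 2 to compound 3 (0.18 log units; within the scatter), most likely a modest drop that may not exceed the scatter. The estimate for compound 3 is 0.4 10^-6 cm/s, with a range from 0.15 10^-6 cm/s to 1 10^-6 cm/s.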

Compound 3, apparent permeability: 0.6 10^-6 cm/s
The estimate for compound 3 lay 1.5-fold (0.18 log units) below the measured number; the measured number falls inside the stated range.
By their numbers in this assay, from the lowest: compounds 1, 2 and 3 (each within the scatter of the next).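

Among the compounds shown here, with ethylamino, the carbonyl carbon now carries a third kind of group in this assay, and the earlier compounds did not show what a group with a hydrogen-bond donor would do there: the exchange of piperidin-1-yl for ethylamino gives no change at the digits printed from compound 2 to compound 3 (within the scatter), and the exchange of ethyl for ethylamino gives a 1.2-fold higher number from compound 1 to compound 3 (0.08 log units; within the scatter). Taken together, the three compounds show no step beyond the scatter at this position, whether the group on the carbonyl carbon has a ring or no ring, and whether it has a hydrogen-bond donor or none, although all three numbers lie in one narrow band and this holds only for these three groups on this core. No independent measurement is available to account for this result.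

The compounds shown leave open whether a carboxylic acid, a primary amine or a longer alkyl chain on the same carbonyl carbon would stay within the scatter of these three in this assay. They also leave open whether a change elsewhere on the shared core, such as in place of the nitrile, would move the number where this position did not.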